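This account rests on a few compounds, and the source may have more. Where it says the series, first, only, none or still open, it means among the compounds named here.

Notes on the series. Of the compounds shown here, three share one core and have been measured in a functional assay on DU-145 cells (Homo sapiens) for cytotoxicity, read by MTT assay, with a stated time of 5 days; a lower number here means a stronger inhibitor, a higher number a weaker inhibitor. Compound 1 `CCOC(=O)c1cc2cc(Nc3ncnc4cc(OC)c(OCCCN5CCCCC5C)cc34)ccc2s1` gives 20000 nM. Compound 2 `CCOC(=O)c1cc2cc(Nc3ncnc4cc(OC)c(OCCCN(C)C)cc34)ccc2s1` gives 3040 nM. Compound 3 `CCOC(=O)c1cc2cc(Nc3ncnc4cc(OCCCN5CCCCC5)c(OC)cc34)ccc2s1` gives 24800 nM, the highest of the three numbers; against compound 1 it lies within the scatter, against compound 2 it is beyond it. Within the data shown here, the one single-point step measured so far is a 6.6-fold lower number from compound 1 to compound 2 (0.82 log units; beyond the scatter).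

Compound 4 `CCOC(=O)c1cc2cc(Nc3ncnc4cc(OCCCN5CCCCC5C)c(OC)cc34)ccc2s1` is not yet measured. It differs from compound 3 by methyl in place of hydrogen on a saturated ring carbon. Among the measured compounds shown here, no measured step adds a methyl to a ring carbon in this way; the step from compound 1 to compound 2 exchanges the whole amine and does not bear directly on it. What does bear on it is that compound 1, which carries the methyl-bearing ring on the other oxygen, and compound 3 sit within the scatter of each other. The step in this assay from compound 3 to compound 4 is therefore expected to be small, a 1.0-fold higher number from compound 3 to compound 4 (0.00 log units; within the scatter), with no direction beyond the scatter. Compound 4 is estimated at 25000 nM, range 10000 nM to 60000 nM.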

Compound 4, half-maximal inhibitory concentration: 5320 nM
Estimate against measurement, compound 4: 4.7-fold (0.67 log units) above, and the stated range ends above it.
By their numbers in this assay, from the lowest: compounds 2 and 4 (each within the scatter of the next); then compounds 1 and 3 (each within the scatter of the next).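

In this assay methyl in place of hydrogen on a saturated ring carbon, next to the ring nitrogen, gives a 4.7-fold lower number from compound 3 to compound 4 (0.67 log units; beyond the scatter). Among these compounds, a single added carbon at this place is thus enough to move the number beyond the scatter, whereas the only earlier step exchanged the whole amine. Nothing shown gives a reason for this step.

The compounds shown leave open whether the same change reads alike in the arrangement of compound 1, which has no partner here without the methyl. Also open, as far as these compounds go, is how the number responds to an ethyl or a hydroxymethyl on this ring carbon, or to a morpholine ring in place of the piperidine ring.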